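Swapping the Benzyl Tail of Compound 2 for Carboxy

The source may hold more compounds than are shown below. What is called first, only, known or untested is meant among the compounds shown, and "the series" means these compounds.

Among the measured compounds shown here, compound 2 `CCCCCCCCc1ccc(OCC(=O)Cn2nnc(Cc3ccccc3)n2)cc1` is the weaker of the two compounds measured so far in an assay on microsomes from brain for inhibition of Fatty-acid amide hydrolase 1 (Rattus norvegicus), read by fluorescence and HPLC, with a stated time of 60 min (on this read-out lower numbers stand for stronger inhibition and higher numbers for weaker inhibition), where compound 2 gives 66 nM. For the measured compounds named here, its partner, compound 1 `CCCCCCCCc1ccc(OCC(=O)Cn2nnc(-c3cccc(Cl)c3)n2)cc1`, gives 24 nM in this assay, and the single measured step, a 2.8-fold higher number from compound 1 to compound 2 (0.44 log units; beyond the scatter), links the two. Compound 3 `CCCCCCCCc1ccc(OCC(=O)Cn2nnc(C(=O)O)n2)cc1` has not yet been measured; it differs from compound 2 in one place, (carboxy in place of benzyl on an aromatic carbon). Going by the values given here, the only measured step concerns an exchange between two aromatic groups and so bears on this change only loosely: it shows that altering the group at this position moves the number by a modest amount. The exchange here is much larger in kind, and a clear weakening is expected. Compound 3 is therefore estimated at 2000 nM in this assay, within a range from 300 nM to 15000 nM, which would mean a step of a 30-fold higher number from compound 2 to compound 3 (1.48 log units; beyond the scatter).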

Compound 3, half-maximal inhibitory concentration: 41 nM
Estimate against measurement, compound 3: 49-fold (1.69 log units) above; measured number outside the range, below it.
By their numbers in this assay, from the lowest: compounds 1, 3 and 2 (each within the scatter of the next, the first and the last beyond it).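

Compound 3 shows that in this assay this position does not need a group with a ring: carboxy in place of benzyl gives a 1.6-fold lower number from compound 2 to compound 3 (0.21 log units; within the scatter) and carboxy in place of 3-chlorophenyl gives a 1.7-fold higher number from compound 1 to compound 3 (0.23 log units; within the scatter) and so neither step rises above the usual scatter. The earlier pair carried a six-membered aromatic ring on both sides, so it could not show that a smaller group with no ring and with a hydrogen-bond donor would stay within the scatter of both. Nothing measured here gives a reason for this result.

From the compounds shown here alone, it remains open whether the hydrogen-bond donor of carboxy matters here, a question that a methyl ester or an amide at the same place could address. Going by these compounds, it also remains open whether a short chain such as ethyl, with no ring and no oxygen, would give a similar number.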